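Replacing the thiophene arm of compound 3 with pyridin-4-yl

The source may report more compounds than this note shows. Statements on the series, on what has been measured and on what is new or still open speak of the compounds shown alone.

Three phenylpropanoic acids sharing one core were examined in an in vitro functional assay on 1321-N1 cells for agonist activity at Free fatty acid receptor 1 (Homo sapiens), read by fluorescence, spectrophotometry and calcium flux; a lower number here means a smaller maximal response, a higher number a larger maximal response. Compound 1 `O=C(O)CCc1ccc(C#Cc2ccnc(-c3ccccc3)c2)cc1` gives 97% in this assay. Compound 2 `O=C(O)CCc1ccc(C#Cc2ccnc(Cl)c2)cc1` gives 94% in this assay; the only measured step that connects two of these compounds, a number 3 percentage points lower from compound 1 to compound 2 (within the scatter), lies within the scatter. Compound 3 `Cc1ccsc1C#Cc1ccc(CCC(=O)O)cc1` gives 100% in this assay, and the values of compound 1 and compound 2 both fall within the scatter of it, so no ordering among the three can be read from these numbers.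

Compound 4 `O=C(O)CCc1ccc(C#Cc2ccncc2)cc1` has not yet been measured in this assay. It differs from compound 3 in one place: pyridin-4-yl in place of 3-methylthiophen-2-yl on a triple-bonded carbon. Going by the values given here, no measured step covers exactly this exchange. The nearest evidence is indirect: compound 1 and compound 2 both carry a substituted pyridin-4-yl on the triple-bonded carbon, and their values sit within the scatter of compound 3, while a number 3 percentage points lower from compound 1 to compound 2 (within the scatter) shows that changing the group on that pyridine moves the maximal response little. On that basis compound 4 is expected to give 96% in this assay, with a range from 86% to 104%. The estimated step of a number 4 percentage points lower from compound 3 to compound 4 (within the scatter) is therefore expected to stay within the scatter.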

Compound 4, largest response reached (reported as efficacy), in percent of the reference or control that the assay uses: 100%
The estimate for compound 4 lay 4 percentage points below the measured number, within the range that was stated.
By their numbers in this assay, from the lowest: compounds 2, 1, 3 and 4 (each within the scatter of the next).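

In this assay, going by these compounds alone, pyridin-4-yl in place of 3-methylthiophen-2-yl on a triple-bonded carbon gives no change at the digits printed from compound 3 to compound 4 (within the scatter), a direct reading of this exchange, which the earlier compounds could only approach indirectly. The bare pyridin-4-yl also completes the comparison among the pyridine compounds: hydrogen in place of chloro on an aromatic carbon gives a number 6 percentage points higher from compound 2 to compound 4 (within the scatter), and hydrogen in place of phenyl gives a number 3 percentage points higher from compound 1 to compound 4 (within the scatter), so neither the chloro nor the phenyl group is required for the maximal response of these compounds in this assay. Nothing at hand offers an explanation for why the response holds across these exchanges.

Going by these compounds, it remains open whether the response would also hold with an amine such as dimethylamino on the pyridin-4-yl, with a longer chain carrying the carboxylic acid, or with an amide in place of that acid. A maximal response also leaves open what concentration of each compound is needed to reach it, so these compounds may yet differ in a way that this read-out cannot show.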